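The source may hold more compounds than are shown below. What is called first, only, known or untested is meant among the compounds shown, and "the series" means these compounds.

Three amides on a shared core have been run through a functional assay on U-87MG ATCC cells for inhibition, with U-87 MG (Homo sapiens) as the target, read by MTT assay, with a stated time of 72 h; on this read-out lower numbers stand for stronger inhibition and higher numbers for weaker inhibition. Compound 1 `CCCNC(=O)c1ccc(Oc2nc(-c3c(C)noc3C)cnc2N)cc1` gives 47800 nM in this assay. Compound 2 `Cc1noc(C)c1-c1cnc(N)c(Oc2ccc(C(=O)NC3CCCC3)cc2)n1` gives 57600 nM. Compound 3 `Cc1noc(C)c1-c1cnc(N)c(Oc2ccc(C(=O)Nc3ccc(Cl)cn3)cc2)n1` gives 45600 nM. Compound 3 has the lowest of the three numbers, yet the steps to both others stay within the scatter: a 1.0-fold lower number from compound 1 to compound 3 (0.02 log units; within the scatter) and a 1.3-fold lower number from compound 2 to compound 3 (0.10 log units; within the scatter), with a 1.2-fold higher number from compound 1 to compound 2 (0.08 log units; within the scatter) between the other pair. Swapping propyl, cyclopentyl or 5-chloropyridin-2-yl on the amide-type nitrogen has thus left the read-out essentially unchanged.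

Compound 4 `Cc1noc(C)c1-c1cnc(N)c(Oc2ccc(C(=O)Nc3cc(Cl)ccn3)cc2)n1` differs from compound 3 only in 4-chloropyridin-2-yl in place of 5-chloropyridin-2-yl on an amide-type nitrogen; the two have the same atoms, joined differently. For the measured compounds named here, no measured step probes a move of the chlorine within the pyridinyl ring. The three steps that do touch this position are all within the scatter, so no step beyond the scatter is expected in this assay for the change from compound 3 to compound 4, that is a 1.1-fold higher number from compound 3 to compound 4 (0.02 log units; within the scatter). Compound 4 is therefore estimated at 48000 nM, with a range from 22000 nM to 100000 nM.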

Compound 4, half-maximal inhibitory concentration: 70800 nM
Estimate against measurement, compound 4: 1.5-fold (0.17 log units) below; the measured number falls inside the stated range.
By their numbers in this assay, from the lowest: compounds 3, 1, 2 and 4 (each within the scatter of the next).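

Moving the chlorine within the pyridinyl ring is now probed directly, and the step stays within the scatter in this assay (a 1.6-fold higher number from compound 3 to compound 4 (0.19 log units; within the scatter)). Compound 4 also stays within the scatter of the two non-aromatic amides (a 1.2-fold higher number from compound 2 to compound 4 (0.09 log units; within the scatter); a 1.5-fold higher number from compound 1 to compound 4 (0.17 log units; within the scatter)), so propyl, cyclopentyl, 5-chloropyridin-2-yl and 4-chloropyridin-2-yl cannot be told apart at this position on this read-out. No supporting data bear on this result.

As far as these compounds go, it remains open whether any group on the amide-type nitrogen departs from this level, such as a chain ending in an amine, a carboxylic acid or an unsubstituted phenyl. The compounds shown also leave open whether a pyridin-2-yl carrying methoxy or nitrile in place of chlorine would read differently.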